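Replacing an aromatic ring with cyclohexyl in an acylguanidine series

A few compounds are considered here, and "the series" means these few. Any claim that something is new, unique, unknown or untested is made for them only; others in the source may bear on it.

For the measured compounds named here, in a functional assay on HEK293T cells for agonist activity at histamine H2 receptor (Homo sapiens), read by beta-arrestin recruitment (on this read-out lower numbers stand for an effect already at smaller amounts and higher numbers for an effect only at larger amounts of compound), compound 1 `Cc1ccc(CC(C)CNC(=O)/N=C(\N)NCCCc2sc(N)nc2C)cc1` gives 132 nM, the lower of the two numbers measured so far; compound 2 `Cc1nc(N)sc1CCCN/C(N)=N/C(=O)NC(c1ccccc1)c1ccccc1` gives 331 nM, a higher number beyond the usual scatter. Compound 3 `Cc1nc(N)sc1CCCN/C(N)=N/C(=O)NCC(C)C1CCCCC1` has not been measured. It differs from compound 1 by cyclohexyl in place of 4-methylbenzyl on a saturated chain carbon bound to two saturated chain carbons. No measured pair shows this change, so the expectation rests on the compounds shown. Compound 3 is expected to give roughly 200 nM, within 70 nM to 600 nM, a small step estimated as a 1.5-fold higher number from compound 1 to compound 3 (0.18 log units; within the scatter), likely not beyond the scatter.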

Compound 3, half-maximal effective concentration: 224 nM
Estimate against measurement, compound 3: 1.1-fold (0.05 log units) below, and the stated range covers the measured number.
By their numbers in this assay, from the lowest: compounds 1, 3 and 2 (each within the scatter of the next, the first and the last beyond it).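

In this assay, cyclohexyl in place of 4-methylbenzyl on a saturated chain carbon bound to two saturated chain carbons gives a 1.7-fold higher number from compound 1 to compound 3 (0.23 log units; within the scatter). At this place, then, the six-membered aromatic ring of compound 1 can give way to a non-aromatic ring of carbon only without a step beyond the scatter. Nothing shown explains this result.

On these data alone, whether this tolerance extends to other rings stays open: cyclopentyl, unsubstituted phenyl and a piperidine, which brings in an amine, could each be placed here. A single pair also cannot show whether the same exchange behaves alike on other chains.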